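Swapping Cyano for Methoxy: What to Expect

A few compounds are considered here, and "the series" means these few. Any claim that something is new, unique, unknown or untested is made for them only; others in the source may bear on it.

In a functional assay on MCF7 cells (Homo sapiens) for cytotoxicity, read by MTT assay, with a stated time of 48 h (on this read-out higher numbers stand for weaker inhibition and lower numbers for stronger inhibition), compound 1 (`OC[C@@H]1C[C@H](CO)[C@@H]2C(c3ccc(Cl)cc3)=NO[C@H]12`) gives 14.7 ug/mL. Compound 2 (`N#Cc1ccc(C2=NO[C@@H]3[C@H](CO)C[C@H](CO)[C@H]23)cc1`) reads > 50 ug/mL, which is a limit of the assay and not a number. From the compounds shown here alone, compound 2 therefore stands at the limit of > 50 ug/mL in this assay, at which 1 of the 2 values shown sits, so its true value is unknown.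

Compound 3 (`COc1ccc(C2=NO[C@@H]3[C@H](CO)C[C@H](CO)[C@H]23)cc1`) keeps the shared core and differs from compound 2 in one group: methoxy in place of cyano on an aromatic carbon. This is methoxy in place of cyano on an aromatic carbon, para to a large group. Within the data shown here, the only measured step bearing on this change is an at least 3.4-fold higher number from compound 1 to compound 2 (0.53 log units; beyond the scatter), which put cyano in place of chloro on an aromatic carbon, and compound 3 gives that cyano up again. A modest move towards lower numbers in this assay is therefore expected. The expectation is loose, since methoxy has not been measured on this core and compound 3 could also end at the limit. The estimated change is an at least 1.7-fold lower number from compound 2 to compound 3 (0.25 log units; that floor lies within the scatter). For compound 3 the expected value is 28 ug/mL, with an estimated range from 12 ug/mL to 60 ug/mL.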

Compound 3, half-maximal inhibitory concentration: 23.7 ug/mL
The estimate for compound 3 lay 1.2-fold (0.07 log units) above the measured number, and the stated range covers the measured number.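

In this assay, going from cyano to methoxy on the same aromatic carbon, para to a large group, gives an at least 2.1-fold lower number from compound 2 to compound 3 (0.32 log units; beyond the scatter), so the weak reading of the cyano compound is not shared by every replacement at this place. Compound 2 remains a limit of the assay and not a number: the limit of > 50 ug/mL in this assay, at which 1 of the 3 values shown sits. Methoxy and chloro cannot be told apart here, the step being a 1.6-fold higher number from compound 1 to compound 3 (0.21 log units; within the scatter), and so cyano is the one group of the three that stands apart, while the two compounds that give numbers read alike within the usual scatter.

With only three groups shown, it stays open whether cyano is the exception at this place or whether many other groups would also read weakly, and an amine, a carboxylic acid or a longer chain such as ethoxy could fall on either side. The true size of the gap between cyano and the other two groups also stays open, and nothing shown says whether the same swaps would read alike on a different core or in a different cell line.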